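Swapping the furan ring for thiophene on a ureide core

This account rests on a few compounds, and the source may have more. Where it says the series, first, only, none or still open, it means among the compounds named here.

Measured compounds:
Compound 1, `CC1=C(C(=O)C2CC2)C(c2ccoc2)NC(=O)N1`, 1%
Compound 2, `CCCC(=O)C1=C(C)NC(=O)NC1c1ccoc1`, 1%
Compound 3, `CC1=C(C(=O)CC(C)C)C(c2ccoc2)NC(=O)N1`, 23%

In an assay on membranes from CHO cells for displacement of a labelled ligand from adenosine receptor A1 (Homo sapiens), read by scintillation counting, with a stated time of 60 min, tested at 1 uM (a higher number here means more inhibition at the concentration tested (going by the name of the read-out), a lower number less inhibition), compound 2 gives 1%, level with compound 1, which gives 1%; together these are the two lowest numbers of the three. Compound 3 stands furthest from compound 2: the step of a number 22 percentage points higher from compound 2 to compound 3 (beyond the scatter).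

Compound 4, `CCCC(=O)C1=C(C)NC(=O)NC1c1ccsc1`, has not been measured. It differs from compound 2 in one place: thiophen-3-yl in place of furan-3-yl on a saturated ring carbon. The propylcarbonyl group and the methyl group of compound 2 are kept.

The measured steps all concern the group on the carbonyl carbon: no change at the digits printed from compound 1 to compound 2 (within the scatter), a number 22 percentage points higher from compound 1 to compound 3 (beyond the scatter), a number 22 percentage points higher from compound 2 to compound 3 (beyond the scatter). Among the compounds with values here, none of them touches the furan-3-yl ring, so no measured step bears directly on the change from compound 2 to compound 4. With nothing to point either way, the expected step of a number 4 percentage points higher from compound 2 to compound 4 (within the scatter) is none beyond the scatter.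

Compound 4 is therefore estimated at 5%, with a range from -10% to 25%.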

Compound 4, a percentage reported as inhibition, at one concentration (the size of the read-out at that concentration, not a potency): 6%
Beside the measured number, compound 4's estimate is 1 percentage points below it; low and high end bracket the measured number.
By their numbers in this assay, from the lowest: compounds 1, 2 and 4 (each within the scatter of the next); then compound 3.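

Among the compounds shown, this is the only step at the saturated ring carbon: in this assay, thiophen-3-yl in place of furan-3-yl gives a number 5 percentage points higher from compound 2 to compound 4 (within the scatter) and so stays within the usual scatter. Sulfur can therefore take the place of oxygen in this ring, with the propylcarbonyl group kept, without a change that can be told from repeat variation. The earlier compounds varied only the group on the carbonyl carbon, so this is a separate observation about a different part of the molecule, and no measurement shown gives a reason for this result.

As far as these compounds go, whether the same swap would also leave the number in place with the isobutyl group of compound 3 remains open. So does the effect of a phenyl group on this ring carbon.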